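A few compounds are considered here, and "the series" means these few. Any claim that something is new, unique, unknown or untested is made for them only; others in the source may bear on it.

In an ADME assay on HEK293 cells (Homo sapiens) for cytotoxicity, with a stated time of 72 h (a lower number here means that less compound is needed, a higher number that more compound is needed for the effect), compound 3 (`Cc1cc(NC(=O)Nc2ccc(SC(F)(F)F)cc2)c2ccccc2n1`) gives 13000 nM, which cannot be told apart from compound 2 (`Cc1cc(NC(=O)Nc2ccc(OC(F)(F)F)cc2)c2ccccc2n1`) at 14000 nM or compound 1 (`CSc1ccc(NC(=O)Nc2cc(C)nc3ccccc23)cc1`) at 24000 nM. Compound 4 (`COc1ccc(NC(=O)Nc2cc(C)nc3ccccc23)cc1`) carries methoxy in place of (trifluoromethyl)sulfanyl on an aromatic carbon. Among the compounds with values here, three measured steps bear on this change: a 1.1-fold lower number from compound 2 to compound 3 (0.03 log units; within the scatter), a 1.8-fold lower number from compound 1 to compound 3 (0.27 log units; within the scatter) and a 1.7-fold lower number from compound 1 to compound 2 (0.23 log units; within the scatter), all within the scatter. Within the data shown here, none of the measured compounds carries methoxy, so the expectation rests on these neighbours alone. No step beyond the scatter is expected in this assay, and the estimated move is a 1.5-fold higher number from compound 3 to compound 4 (0.19 log units; within the scatter). For compound 4 the expected value is 20000 nM, with an estimated range of 9000 nM to 45000 nM.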

Compound 4, half-maximal effective concentration: > 25000 nM
Compound 4 gave a limit, no number; the forecaster's own chance of this, stated with the estimate: 15%; at least 1.2-fold (0.09 log units) between middle value and limit.
By their numbers in this assay, from the lowest: compounds 3, 2 and 1 (each within the scatter of the next). At a limit, above all of these: compound 4.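

Within the data shown here, compound 4, the only one here whose group on the aromatic carbon holds neither fluorine nor sulfur, gives > 25000 nM in this assay, which is a limit and not a number. The steps are an at least 1.9-fold higher number from compound 3 to compound 4 (0.28 log units; that floor lies within the scatter), an at least 1.7-fold higher number from compound 2 to compound 4 (0.25 log units; that floor lies within the scatter) and an at least 1.0-fold higher number from compound 1 to compound 4 (0.01 log units; that floor lies within the scatter), so methoxy cannot yet be separated from the other three groups at this position. Its reading is the only one at the limit: the limit of > 25000 nM in this assay, at which 1 of the 4 values shown sits.

From the compounds shown here alone, how far compound 4 really lies from the others stays open. So does the outcome at this position with an amine, a carboxylic acid or a longer chain.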